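A few compounds are considered here, and "the series" means these few. Any claim that something is new, unique, unknown or untested is made for them only; others in the source may bear on it.

Measured in a functional assay on L1210 cells (Mus musculus) for antiproliferative activity, read by MTT assay, with a stated time of 72 h; on this read-out higher numbers stand for weaker inhibition and lower numbers for stronger inhibition:
- compound 1 `COc1cc(/C(=C/c2cccc([N+](=O)[O-])c2)C(C)O)cc(OC)c1OC`: > 100000 nM
- compound 2 `COc1ccc(/C=C(/c2cc(OC)c(OC)c(OC)c2)C(C)O)cc1OC`: 69000 nM
- compound 3 `COc1ccc(/C=C(/c2cc(OC)c(OC)c(OC)c2)C(C)O)cc1O`: 4100 nM

The entry for compound 1 is a limit of the assay, not a number. Of the two actual numbers, compound 3 has the lower, and compound 2 is its nearest neighbour. Compound 4 `COc1ccc(/C=C(/c2cc(OC)c(OC)c(OC)c2)C(C)O)cc1[N+](=O)[O-]` is still unmeasured. It has nitro in place of hydroxy on an aromatic carbon, ortho to a methoxy group: nitro in place of hydroxy on an aromatic carbon.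

Among the measured compounds shown here, the one measured step at this place is a 17-fold lower number from compound 2 to compound 3 (1.23 log units; beyond the scatter), which is large and beyond the scatter. Compound 2 lacks the hydroxy and has the higher number, so losing the hydroxy in compound 4 points the same way. For the measured compounds named here, compound 1 is the only measured compound with a nitro group, and it sits at the limit described by the limit of > 100000 nM in this assay, at which 1 of the 3 values shown sits, though on a differently substituted core. A sizeable rise in this assay is therefore expected, probably smaller than the measured step, as an estimated 4.9-fold higher number from compound 3 to compound 4 (0.69 log units; beyond the scatter). For compound 4 the expected value is 20000 nM, with an estimated range of 5000 nM to 90000 nM.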

Compound 4, half-maximal inhibitory concentration: 67500 nM
Compound 4: the middle estimate sits 3.4-fold (0.53 log units) below what was measured; the measured number falls inside the stated range.
By their numbers in this assay, from the lowest: compound 3; then compounds 4 and 2 (each within the scatter of the next). At a limit, above all of these: compound 1.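

Replacing the hydroxy of compound 3 with nitro gives a 16-fold higher number from compound 3 to compound 4 (1.22 log units; beyond the scatter) in this assay, so the lower number at this position is not simply a matter of removing the methyl of a methoxy group, as the earlier step alone might have suggested. Nitro and methoxy at this place cannot be told apart, with a 1.0-fold lower number from compound 2 to compound 4 (0.01 log units; within the scatter), which leaves hydroxy the only one of the three groups here on the shared core with a clearly lower number. The step of an at least 1.4-fold lower number from compound 1 to compound 4 (0.17 log units; that floor lies within the scatter) starts from a limit of the assay and not a number, so it cannot be read as a change: the limit of > 100000 nM in this assay, at which 1 of the 4 values shown sits.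

On these data alone, whether an amine or a carboxylic acid at this place would behave like hydroxy or like nitro remains open. So does whether hydroxy would lower the number on the core of compound 1.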